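This account rests on a few compounds, and the source may have more. Where it says the series, first, only, none or still open, it means among the compounds named here.

In an ADME assay on J774.A1 cells (Mus musculus) for cytotoxicity, read by MTT assay, with a stated time of 72 h (on this read-out higher numbers stand for lower toxicity in this test and lower numbers for higher toxicity in this test), compound 1 `Nc1nc(-c2ccccc2)cc(-c2ccc(C3NC(=O)c4ccccc4N3)cc2)n1` has the entry "not determined" (no result reported), compound 2 `COc1cc(-c2cc(-c3ccc(C4NC(=O)c5ccccc5N4)cc3)nc(N)n2)cc(OC)c1OC` gives 103000 nM and compound 3 `CN1CCN(c2ccc(-c3cc(-c4ccc(C5NC(=O)c6ccccc6N5)cc4)nc(N)n3)cc2)CC1` gives 10200 nM, the lower of the two numbers. Compound 3 therefore stands as the more toxic of the two compounds with a number in this assay. Compound 4 `Nc1nc(-c2ccc(Cl)cc2)cc(-c2ccc(C3NC(=O)c4ccccc4N3)cc2)n1` keeps the core of compound 3 and differs from it in one place: chloro in place of 4-methylpiperazin-1-yl on an aromatic carbon. Among the compounds with values here, no measured step between these compounds isolates this change. Compound 2 also lacks the 4-methylpiperazin-1-yl group and gives 103000 nM, so a moderate rise beyond the scatter is expected in this assay. The estimated step is a 3.9-fold higher number from compound 3 to compound 4 (0.59 log units; beyond the scatter). For compound 4 the expected value is 40000 nM, with an estimated range from 12000 nM to 130000 nM.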

Compound 4, half-maximal cytotoxic concentration: 82200 nM
Compound 4: middle estimate off by 2.1-fold (0.31 log units), on the low side, and the stated range covers the measured number.
By their numbers in this assay, from the lowest: compound 3; then compounds 4 and 2 (each within the scatter of the next).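

In this assay the exchange of 4-methylpiperazin-1-yl for chloro at this position gives an 8.1-fold higher number from compound 3 to compound 4 (0.91 log units; beyond the scatter) and so ties the lower number of compound 3 to the 4-methylpiperazin-1-yl group within this pair. The step of a 1.3-fold lower number from compound 2 to compound 4 (0.10 log units; within the scatter) shows that 4-chlorophenyl and 3,4,5-trimethoxyphenyl are not told apart in this test. Nothing available explains these steps. From the compounds shown here alone, it remains open whether the lower number needs the whole 4-methylpiperazin-1-yl ring or would also appear with an open-chain amine such as dimethylamino or with a morpholine ring.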